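Nitro in place of fluoro in compound 3

A few compounds are considered here, and "the series" means these few. Any claim that something is new, unique, unknown or untested is made for them only; others in the source may bear on it.

In a functional assay on MCF7 cells (Homo sapiens) for inhibition, read by CCK-8 assay, with a stated time of 48 h (on this read-out lower numbers stand for stronger inhibition and higher numbers for weaker inhibition), compound 1 `COc1cc(-c2ccnc3cc(-c4ccc(C(F)(F)F)cc4)nn23)cc(OC)c1OC` gives 2440 nM and compound 2 `COc1ccc(-c2cc3nccc(-c4cc(OC)c(OC)c(OC)c4)n3n2)cc1F` gives 183 nM as the lower number of the two. Compound 3 `COc1ccc(-c2cc3nccc(-c4cc(OC)c(OC)c(OC)c4)n3n2)cc1[N+](=O)[O-]` differs through nitro in place of fluoro on an aromatic carbon as nitro in place of fluoro on an aromatic carbon. Within the data shown here, the only measured step of a 13-fold lower number from compound 1 to compound 2 (1.12 log units; beyond the scatter) was large and swapped the whole substituted phenyl group, so it shows that this part can move the number but does not compare nitro with fluoro. A moderately higher number is therefore expected, with a 2.2-fold higher number from compound 2 to compound 3 (0.34 log units; beyond the scatter) as the estimated step. Compound 3 is estimated at 400 nM with 110 nM and 1500 nM as the ends of the expected range.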

Compound 3, half-maximal inhibitory concentration: > 10000 nM
Compound 3: only a limit was reported; the forecaster's own chance of this, stated with the estimate: 3%; at least 25-fold (1.39 log units) between middle value and limit.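

For compound 3 only a limit was reported in this assay: the limit of > 10000 nM in this assay, at which 1 of the 3 values shown sits. Read against that limit, the exchange on this aromatic carbon, ortho to a methoxy group, gives an at least 54-fold higher number from compound 2 to compound 3 (1.73 log units; beyond the scatter). The earlier step replaced a whole substituted phenyl group, whereas this one shows that changing fluoro alone, with the rest of the structure unchanged, is enough to produce a large step.

Going by these compounds, how far compound 3 lies past its limit stays open. The compounds shown also leave open how an amine, chlorine or plain hydrogen at this place would read.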